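Replacing the octyl chain of compound 3 with a trifluoromethylphenoxy group

The source may hold more compounds than are shown below. What is called first, only, known or untested is meant among the compounds shown, and "the series" means these compounds.

Compound 1 `CCCCCCCCc1ccc(OCC(=O)Cn2nnc(-c3ccc(C(=O)OC)cc3)n2)cc1` gives 8 in a physicochemical assay for lipophilicity, read by HPLC, tested at 5 mM; a higher number here means a more lipophilic compound, a lower number a more polar compound. Compound 2 `CCCCCCCCc1ccc(OCC(=O)Cn2nnc(C(=O)O)n2)cc1` gives 5.3. For the measured compounds named here, the single measured step, a number 2.70 log units lower from compound 1 to compound 2 (beyond the scatter), is the only one available. For compound 3 `CCCCCCCCc1ccc(OC(C)C(=O)Cn2nnc(-c3ccccc3)n2)cc1` the assay reports only a limit, > 8, which is the limit noted in the limit of > 8 in this assay, at which 1 of the 3 values shown sits. Compound 4 `CC(Oc1ccc(Oc2ccc(C(F)(F)F)cc2)cc1)C(=O)Cn1nnc(-c2ccccc2)n1` differs from compound 3 by 4-(trifluoromethyl)phenoxy in place of octyl on an aromatic carbon. Going by the values given here, no measured step follows this kind of exchange, so the step from compound 1 to compound 2 gives no direct guidance. The expectation is therefore a modest change, estimated as a number at least 0.50 log units lower from compound 3 to compound 4 (beyond the scatter), in the downward direction but possibly within the scatter. Compound 4 is estimated at 7.5, between 6.5 and 8.5.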

Compound 4, partition coefficient: 6.2
Beside the measured number, compound 4's estimate is 1.30 log units above it, outside the stated range (below it).
By their numbers in this assay, from the lowest: compound 2; then compound 4; then compound 1.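

In this assay, 4-(trifluoromethyl)phenoxy in place of octyl gives a number at least 1.80 log units lower from compound 3 to compound 4 (beyond the scatter), which shows that this position, para to a large group, can carry a large change in the read-out even though the entering group has more heavy atoms than the chain it replaces. Compound 3 has only a limit, so this step marks a minimum size and not an exact one: the limit of > 8 in this assay, at which 1 of the 4 values shown sits.

The compounds shown leave open whether the change follows the ring, the ether oxygen or the trifluoromethyl group. A plain phenoxy group or a butyl chain at this position would begin to separate these.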